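The source may hold more compounds than are shown below. What is called first, only, known or untested is meant among the compounds shown, and "the series" means these compounds.

Measured in a functional assay on ACHN cells (feces, Homo sapiens); a lower number here means a stronger inhibitor, a higher number a weaker inhibitor:
Compound 1 `COC(=O)c1nn([C@@H]2O[C@H](CO)[C@@H](O)[C@H]2O)cc1I`: 3600 nM
Compound 2 `O=C(O)c1nn([C@@H]2O[C@H](CO)[C@@H](O)[C@H]2O)cc1I`: > 300000 nM, a limit
Compound 3 `CCCCOC(=O)c1nn([C@@H]2O[C@H](CO)[C@@H](O)[C@H]2O)cc1I`: "not determined" (no result reported)

Compound 3 has no place on the scale of this assay. From the compounds shown here alone, its entry reads "not determined" (no result reported), so the starting point of this step is unknown. Among the compounds with values here, the only number is that of compound 1, at 3600 nM. Compound 2 stands at > 300000 nM, which is a limit and not a number.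

Compound 4 `Cc1noc(-c2nn([C@@H]3O[C@H](CO)[C@@H](O)[C@H]3O)cc2I)n1` differs from compound 3 as follows: 3-methyl-1,2,4-oxadiazol-5-yl in place of butoxycarbonyl on an aromatic carbon. In short, 3-methyl-1,2,4-oxadiazol-5-yl stands in place of butoxycarbonyl on an aromatic carbon, and neither group has a measured result here.

Within the data shown here, only one measured step bears on this change, and it does so indirectly. The step of an at least 83-fold higher number from compound 1 to compound 2 (1.92 log units; beyond the scatter) is large and shows that a change at this same carbon's substituent can cost a great deal of activity. It does not involve either group, and with no number for compound 3, no size or direction can be expected for the change to compound 4. The expectation therefore leans on compound 1 at 3600 nM, with wide margins on both sides. For compound 4 the expected value is 8000 nM, with an estimated range from 800 nM to 100000 nM.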

Compound 4, half-maximal inhibitory concentration: 6200 nM
Beside the measured number, compound 4's estimate is 1.3-fold (0.11 log units) above it; the range from low to high includes it.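

In this assay, the 3-methyl-1,2,4-oxadiazol-5-yl group shows that this aromatic carbon can carry a five-membered aromatic ring in place of an ester with no readable change, as methoxycarbonyl gives way to it with a 1.7-fold higher number from compound 1 to compound 4 (0.24 log units; within the scatter). Set against the carboxy group, the same ring gives an at least 48-fold lower number from compound 2 to compound 4 (1.68 log units; beyond the scatter), so among the compounds shown, the activity at this carbon is not tied to the ester itself, and only the carboxy compound stands apart. This second step starts from a limit and not a number, the one held by compound 2: the limit of > 300000 nM in this assay, at which 1 of the 4 values shown sits.

From the compounds shown here alone, compound 3 has no result, so its step to compound 4 cannot be read, and the effect of the butoxycarbonyl chain at this carbon remains unknown. Also open, going by these compounds, is how a primary amide or a nitrile would compare at this carbon, whether an ethyl or phenyl group could stand in place of the methyl on the oxadiazole, and what would follow if a bromo group or a hydrogen replaced the iodo group on the neighbouring ring atom.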